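A few compounds are considered here, and "the series" means these few. Any claim that something is new, unique, unknown or untested is made for them only; others in the source may bear on it.

Compound 2 `C#Cc1cc(C(F)(F)F)cc(C(F)(F)F)c1` carries an ethynyl group on its aromatic ring. In an ADME assay for pharmacokinetics, read by HPLC, in phosphate buffer, with a stated time of 72 h, at pH 7.4, tested at 250 uM (a higher number here means that the compound lasts longer, a lower number that the compound disappears faster), compound 2 gives > 50 h, which is a limit of the assay and not a number. Compound 1 `C=Cc1cc(C(F)(F)F)cc(C(F)(F)F)c1`, which bears a vinyl group in place of the ethynyl, gives > 50 h in this assay, again a limit. Going by the values given here, the step that the two limits leave unreadable from compound 1 to compound 2 therefore cannot be sized, and the only evidence on the measured steps is the limit of > 50 h in this assay, at which 2 of the 2 values shown sit. Compound 3 `FC(F)(F)c1cc(C2CO2)cc(C(F)(F)F)c1` has not yet been measured; it differs from compound 2 by oxiran-2-yl in place of ethynyl on an aromatic carbon. No measured step bears on this change, since the single step shown is unreadable, and the shared core has so far only reached the upper limit in this assay. The uncertainty is accordingly wide. For compound 3 the expected step is an at least 1.2-fold lower number from compound 2 to compound 3 (0.09 log units; that floor lies within the scatter) in this assay. Compound 3 is estimated at 40 h, with a range from 12 h to 120 h.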

Compound 3, half-life: 6 h
The estimate for compound 3 lay 6.7-fold (0.82 log units) above the measured number; the measured number lies below the stated range.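

In this assay, this position shows its first readable change: oxiran-2-yl in place of ethynyl gives an at least 8.3-fold lower number from compound 2 to compound 3 (0.92 log units; beyond the scatter), and oxiran-2-yl in place of vinyl gives an at least 8.3-fold lower number from compound 1 to compound 3 (0.92 log units; beyond the scatter). Both steps lie beyond the scatter, whereas the step between compound 1 and compound 2 cannot be read. The full size of both steps stays unknown, because each starts from a limit of the assay and not from a number: the limit of > 50 h in this assay, at which 2 of the 3 values shown sit.

The compounds shown leave open whether the lower number goes with the three-membered ring itself or with the oxygen atom it holds. A cyclopropyl group, which keeps the three-membered ring without the oxygen, or an open-chain ether such as methoxymethyl, which keeps the oxygen without the ring, would separate the two at this position.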